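Caffeate glycolamides: chlorophenyl amide placed on the free catechol

The compounds below may be only part of what the source reports. "The series", "measured", "known", "first", "only" and "open" are said of these compounds alone.

Working notes on the cytotoxic ester series. Compound 1 `COCOc1cc(/C=C/C(=O)OCC(=O)Nc2ccc(Cl)cc2)ccc1OCc1ccccc1` carries the protected catechol together with the 4-chlorophenyl amide; in a functional assay on HL-60 cells (Homo sapiens) for cytotoxicity, read by MTT assay, with a stated time of 72 h (on this read-out lower numbers stand for stronger inhibition and higher numbers for weaker inhibition), compound 1 gives only a limit, > 200000 nM. Compound 2 `O=C(COC(=O)/C=C/c1ccc(O)c(O)c1)NN1CCOCC1` keeps the free catechol with a morpholin-4-yl amide; in this assay compound 2 likewise reaches only a limit, > 200000 nM. Among the measured compounds shown here, compound 2 therefore stands at the limit of the assay, as does the one other value shown, and no step between measured compounds can be computed (the limit of > 200000 nM in this assay, at which 2 of the 2 values shown sit). Compound 3 `O=C(COC(=O)/C=C/c1ccc(O)c(O)c1)Nc1ccc(Cl)cc1` differs from compound 2 by 4-chlorophenyl in place of morpholin-4-yl on an amide-type nitrogen. Each measured compound holds one part of compound 3, the free catechol in compound 2 and the 4-chlorophenyl amide in compound 1, and each sits at the limit. The step from compound 2 to compound 3 is expected to be none beyond the scatter, a number no higher from compound 2 to compound 3 (the limit leaves the size open), with compound 3 most likely again reported as a limit. Compound 3 is estimated at 200000 nM, within 60000 nM to 400000 nM.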

Compound 3, half-maximal inhibitory concentration: 8100 nM
The estimate for compound 3 lay 25-fold (1.39 log units) above the measured number; the measured number lies below the stated range.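

In this assay, the amide-type nitrogen of the free-catechol series proves to be a position that matters: 4-chlorophenyl in place of morpholin-4-yl gives an at least 24-fold lower number from compound 2 to compound 3 (1.39 log units; beyond the scatter). Compound 3 is the only one of the three compounds shown to give a number rather than a limit, so the free catechol with a morpholin-4-yl amide, as in compound 2, is not enough for a measurable value on this read-out. The size of the step is open-ended, since compound 2 stands at a limit of the assay: the limit of > 200000 nM in this assay, at which 2 of the 3 values shown sit.

Going by these compounds, whether phenyl without chlorine, 4-fluorophenyl or 4-aminophenyl on this nitrogen would keep a measurable value remains open. Also open, on these data alone, is how much of the value of compound 3 depends on the free catechol, which a single hydroxyl or a dimethyl ether in its place would test.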